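Three Inactive Analogues and an Untested Demethylated Fourth

A few compounds are considered here, and "the series" means these few. Any claim that something is new, unique, unknown or untested is made for them only; others in the source may bear on it.

Compound 1 `Cn1c(-c2cc(-c3ccc[nH]3)no2)cc(Br)c1Br`, compound 2 `Cn1c(-c2cc(-c3ccccc3O)no2)cc(Br)c1Br` and compound 3 `Brc1cc(-c2cc(-c3ccc[nH]3)no2)[nH]c1Br` were tested in a functional assay on WRL68 cells (Homo sapiens) for cytotoxicity, read by MTT assay, with stated times of 6 h and 48 h; on this read-out lower numbers stand for stronger inhibition and higher numbers for weaker inhibition. Compound 1 gives >= 100000 nM, which is a limit of the assay rather than a number. Compound 2 likewise gives only a limit, >= 100000 nM. Compound 3 too gives a limit, >= 100000 nM. All three values sit at the limit of >= 100000 nM in this assay, at which 3 of the 3 values shown sit. Compound 3 differs from compound 1 by hydrogen in place of methyl on an aromatic nitrogen, and the step that the two limits leave unreadable from compound 1 to compound 3. The difference between the cores of compound 1 and compound 2 is not broken down here. Compound 4 `Oc1ccccc1-c1cc(-c2cc(Br)c(Br)[nH]2)on1` has not yet been measured; it differs from compound 2 by hydrogen in place of methyl on an aromatic nitrogen, the same change. In this assay compound 4 is expected to give about 120000 nM, between 50000 nM and 300000 nM, an expected step that the limit leaves unreadable from compound 2 to compound 4, because compound 2 gives >= 100000 nM and the same change from compound 1 to compound 3 stayed at the limit.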

Compound 4, half-maximal inhibitory concentration: >= 100000 nM
Compound 4 gave a limit, no number; the forecaster's own chance of this, stated with the estimate: 85%; the middle value lies beyond the limit too.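

Compound 2 and compound 4 both give only a limit, so no step can be read between them: the limit of >= 100000 nM in this assay, at which 4 of the 4 values shown sit.

The compounds shown leave open whether hydrogen in place of methyl makes any difference in this assay.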